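The source may report more compounds than this note shows. Statements on the series, on what has been measured and on what is new or still open speak of the compounds shown alone.

Compound 3, `CC1(C)C[C@H](Nc2cc(NCc3cnccc3C(F)(F)F)ncc2C#N)CC[C@H]1O`, belongs to a small set built on one shared core. In an assay on isolated protein for inhibition of protein kinase C delta type (Homo sapiens), read by TR-FRET, with a stated time of 2 h (on this read-out lower numbers stand for stronger inhibition and higher numbers for weaker inhibition), compound 3 gives 2200 nM, the highest of the two plain numbers. Compound 2, `CNC(=O)[C@H]1CC[C@@H](Nc2cc(NCc3cnccc3C(F)(F)F)ncc2C#N)CC1`, gives 1600 nM, and the step of a 1.4-fold higher number from compound 2 to compound 3 (0.14 log units; within the scatter) stays within the scatter. Compound 1, `N#Cc1cnc(NCc2cnccc2C(F)(F)F)cc1NCCC1CCOCC1`, gives only a limit of the assay, > 10000 nM. The steps of an at least 6.2-fold lower number from compound 1 to compound 2 (0.79 log units; beyond the scatter) and an at least 4.5-fold lower number from compound 1 to compound 3 (0.65 log units; beyond the scatter) each exchanged one group on a nitrogen on an aromatic ring for another. Compound 4, `CC1(C)C[C@@H](Nc2cc(NCc3cnccc3C(F)(F)F)ncc2C#N)CC[C@@H]1O`, differs from compound 3 by the two compounds have the same atoms and bonds and differ only in configuration as drawn: 2 of 2 stereo elements differ (all stereocentres are inverted: mirror images); a stereocentre at a saturated ring carbon is drawn R in compound 3 and S in compound 4; a stereocentre at a saturated ring carbon is drawn R in compound 3 and S in compound 4. Among the compounds with values here, none of the measured steps is a mirror-image change, so they offer no guide to direction or size here. Compound 4 is expected at 3000 nM, between 800 nM and 15000 nM. This expected step is a 1.4-fold higher number from compound 3 to compound 4 (0.13 log units; within the scatter).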

Compound 4, half-maximal inhibitory concentration: 2400 nM
Estimate against measurement, compound 4: 1.3-fold (0.10 log units) above; the range from low to high includes it.
By their numbers in this assay, from the lowest: compounds 2, 3 and 4 (each within the scatter of the next). At a limit, above all of these: compound 1.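

Compound 3 and compound 4 are mirror images, and in this assay they read alike: a 1.1-fold higher number from compound 3 to compound 4 (0.04 log units; within the scatter). The comparison with the 4-(methylcarbamoyl)cyclohexyl group therefore holds for either mirror image: a 1.5-fold higher number from compound 2 to compound 4 (0.18 log units; within the scatter). Compound 1 stands at a limit of the assay, not at a number, and the separation from it also holds for both mirror images: an at least 4.1-fold lower number from compound 1 to compound 4 (0.61 log units; beyond the scatter).

Still open, on these data alone, is whether inverting only one of the two stereocentres gives the same reading. Also open, as far as these compounds go, is whether an amine or a carboxylic acid in place of the hydroxyl on this cyclohexyl group would hold the value.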